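The source may hold more compounds than are shown below. What is called first, only, known or untested is meant among the compounds shown, and "the series" means these compounds.

Compound 1 `CC1(C)c2[nH]nc(NC(=O)c3ccccc3)c2CN1Cc1ccccc1` carries a plain benzyl group on the ring nitrogen of the shared core. In an assay on Sf21 cells for inhibition of high affinity nerve growth factor receptor (Homo sapiens), read by HTRF, with a stated time of 30 min, in the presence of a further agent that is not named here (on this read-out higher numbers stand for weaker inhibition and lower numbers for stronger inhibition), compound 1 gives 1240 nM. Compound 2 `CC1(C)c2[nH]nc(NC(=O)c3ccccc3)c2CN1Cc1cc(F)ccc1F` differs only in that benzyl ring, and in this assay compound 2 gives 480 nM. The change, 2,5-difluorophenyl in place of phenyl on a saturated chain carbon bound to an amine nitrogen in a ring, brings a 2.6-fold lower number from compound 1 to compound 2 (0.41 log units; beyond the scatter). Within the data shown here, of the two numbers measured so far, compound 2 has the lowest, with compound 1 the nearest and standing higher by that same step. Compound 3 `Cc1ccc(F)c(CN2Cc3c(NC(=O)c4ccccc4)n[nH]c3C2(C)C)c1` has not yet been measured. It differs from compound 2 by methyl in place of fluoro on an aromatic carbon. Among the measured compounds shown here, only one measured step touches this part of the molecule, a 2.6-fold lower number from compound 1 to compound 2 (0.41 log units; beyond the scatter), and it added two fluorines rather than trading one fluorine for a methyl, so it bears on the new change only loosely and gives no guide to direction. A change of modest size at most is therefore expected in this assay. The estimated step is a 1.0-fold higher number from compound 2 to compound 3 (0.02 log units; within the scatter). Compound 3 is expected to give about 500 nM, within a range from 200 nM to 1300 nM.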

Compound 3, half-maximal inhibitory concentration: 880 nM
For compound 3 the middle estimate is 1.8-fold (0.25 log units) below the measured one; measured number inside the range.
By their numbers in this assay, from the lowest: compounds 2, 3 and 1 (each within the scatter of the next, the first and the last beyond it).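

In this assay, trading fluoro for methyl on this aromatic carbon, para to a fluoro group, gives a 1.8-fold higher number from compound 2 to compound 3 (0.26 log units; within the scatter), so on these numbers the position takes a methyl group without a change that can be told from ordinary assay noise. The 2-fluoro-5-methylphenyl group also cannot be separated from plain phenyl, with a 1.4-fold lower number from compound 1 to compound 3 (0.15 log units; within the scatter), which places compound 3 within the scatter of both neighbours even though compound 1 and compound 2 stand beyond the scatter of each other, so this result cannot show whether the fluoro group at this position matters to the earlier step. Nothing available here offers an explanation for these numbers.

The compounds shown leave open how much of the step between compound 1 and compound 2 belongs to each of the two fluoro groups, a question that a benzyl ring carrying only one fluoro group at this position could help to settle. They also leave open how this position would respond to a larger or different group, such as methoxy, chloro or an amine.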